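Allylic amine to fluoride on an acrylamide anilide series

The source may hold more compounds than are shown below. What is called first, only, known or untested is meant among the compounds shown, and "the series" means these compounds.

Working notes on the series. Within the data shown here, compound 1 `O=C(/C=C/CN1CCCCC1)Nc1ccccc1` is the only compound of the set with a number rather than a limit in an ADME assay for pharmacokinetics, read by LC-MS, in phosphate buffer, with a stated time of 120 min, at pH 7.4, tested at 1 uM, in the presence of a further agent that is not named here; on this read-out lower numbers stand for a shorter-lived compound and higher numbers for a longer-lived compound: compound 1 gives 2.95 h. Compound 2 `O=C(/C=C/CC(=O)Nc1ccccc1)Nc1ccccc1` reaches only a limit of the assay in this assay, with compound 2 at > 8.53 h; this matches (the limit of > 8.53 h in this assay, at which 1 of the 2 values shown sits). Among the measured compounds shown here, no measured step between two compounds that differ in one place is available, so the size of the step from compound 1 to compound 3 has no direct comparison within the set.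

Compound 3 `O=C(/C=C/CF)Nc1ccccc1` differs from compound 1 by fluoro in place of piperidin-1-yl on a saturated chain carbon bound to a double-bonded chain carbon. The change is expected to move the half-life in this assay only modestly, likely toward a longer-lived compound, with the step from compound 1 to compound 3 estimated as a 1.4-fold higher number from compound 1 to compound 3 (0.13 log units; within the scatter). Compound 3 is therefore expected to give about 4 h in this assay, with a range from 1.5 h to 10 h.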

Compound 3, half-life: > 8.53 h
Compound 3: only a limit was reported (the forecaster's own chance of this, stated with the estimate: 20%); middle value at least 2.1-fold (0.32 log units) away from the limit.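

In this assay, fluoro in place of piperidin-1-yl on a saturated chain carbon bound to a double-bonded chain carbon gives an at least 2.8-fold higher number from compound 1 to compound 3 (0.46 log units; beyond the scatter), so the half-life responds to the group at this position and does not depend on keeping the piperidin-1-yl ring. The step is only a lower bound: the value of compound 3, > 8.53 h, is a limit of the assay and not a number. Compound 1 thus remains the only compound with a number, and the full size of the step cannot be read: the limit of > 8.53 h in this assay, at which 2 of the 3 values shown sit.

The compounds shown leave open whether the shorter half-life of compound 1 belongs to the piperidin-1-yl ring in particular or to amines on this carbon in general, which a dimethylamino group or a morpholine on the same carbon would separate. Also open, from the compounds shown here alone, is how far past the limit compound 3 lies.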